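Swapping a Cyclohexyl for a Fluorobenzyl on the Shared Core

The source may report more compounds than this note shows. Statements on the series, on what has been measured and on what is new or still open speak of the compounds shown alone.

Of the compounds shown here, three built on one shared core have been measured in a physicochemical assay for acid dissociation. Compound 1 `COc1cccc(CNCCCNc2ccnc3cc(C4CCCCC4)ccc23)c1O` gives 9.47. Compound 2 `COc1ccc(F)cc1CNCCCNc1ccnc2cc(C3CCCCC3)ccc12` gives 9.47. Compound 3 `COc1cccc(CNCCCNc2ccnc3cc(-c4ccc(F)cc4)ccc23)c1O` gives 9.47. Compound 2 therefore stands level with compound 1 and with compound 3 at the digits shown; its nearest neighbour is compound 1 and its furthest is compound 3, and both gaps lie within the scatter. The two steps seen so far, no change at the digits printed from compound 1 to compound 2 (within the scatter) and no change at the digits printed from compound 1 to compound 3 (within the scatter), were both flat.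

Compound 4 `COc1ccc(F)cc1CNCCCNc1ccnc2cc(Cc3ccc(F)cc3)ccc12` has not yet been measured. Its change from compound 2 is 4-fluorobenzyl in place of cyclohexyl on an aromatic carbon. For the measured compounds named here, the step that bears most directly on it is the one from compound 1 to compound 3, where a cyclohexyl on an aromatic carbon of the core was also replaced, by 4-fluorophenyl, and the result was no change at the digits printed from compound 1 to compound 3 (within the scatter). By that comparison the step from compound 2 to compound 4 is expected to be no change at the digits printed from compound 2 to compound 4 (within the scatter), that is, nothing beyond the scatter. Compound 4 is estimated at 9.47, with a range from 9.2 to 9.75.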

Compound 4, acid dissociation constant: 9.47
The estimate for compound 4 equals the measured number at the digits printed; low and high end bracket the measured number.
By their numbers in this assay, from the lowest: compounds 1, 2, 3 and 4 (each within the scatter of the next).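

Replacing cyclohexyl with 4-fluorobenzyl on the aromatic carbon leaves the reading in this assay flat, with no change at the digits printed from compound 2 to compound 4 (within the scatter). For the compounds shown here, this extends what the earlier compounds showed: the position takes a group of 8 heavy atoms with a six-membered aromatic ring in place of one of 6 heavy atoms with a non-aromatic ring, and the reading stays level while the other end of the molecule carries 5-fluoro-2-methoxyphenyl rather than 2-hydroxy-3-methoxyphenyl. No supporting measurement is available to explain this flat step.

The groups shown at this position all lack an ionisable atom, so the reading with an amine or a carboxylic acid there remains open. A longer chain between the core and the 4-fluorophenyl ring is also an open case.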